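The source may report more compounds than this note shows. Statements on the series, on what has been measured and on what is new or still open speak of the compounds shown alone.

Measured so far:
compound 1 `CN(C)CCN1CCN(c2ccc(Cn3c(=O)[nH]c4c(N)nc(C(F)(F)F)cc43)cn2)CC1` gives 0.1 10^-6 cm/s
compound 2 `Nc1nc(C(F)(F)F)cc2c1[nH]c(=O)n2Cc1ccc(NCCN2CCCCC2)nc1` gives 0.3 10^-6 cm/s
compound 3 `CN(CCN1CCCCC1)c1ccc(Cn2c(=O)[nH]c3c(N)nc(C(F)(F)F)cc32)cn1` gives 5.2 10^-6 cm/s

In an ADME assay for permeability, using PAMPA (a higher number here means that the compound crosses the layer faster, a lower number that the compound crosses the layer more slowly), compound 2 sits in the middle of the three: above compound 1 by a 3.0-fold higher number from compound 1 to compound 2 (0.48 log units; beyond the scatter) and below compound 3 by a 17-fold higher number from compound 2 to compound 3 (1.24 log units; beyond the scatter). Compound 4 `CN1CCN(CCN(C)c2ccc(Cn3c(=O)[nH]c4c(N)nc(C(F)(F)F)cc43)cn2)CC1` is not yet measured; its change from compound 2 is methyl(2-(4-methylpiperazin-1-yl)ethyl)amino in place of (2-(piperidin-1-yl)ethyl)amino on an aromatic carbon. Among the compounds with values here, two measured steps bear on this. The step of a 17-fold higher number from compound 2 to compound 3 (1.24 log units; beyond the scatter) is the same methyl for hydrogen on the ring nitrogen, while the step of a 52-fold higher number from compound 1 to compound 3 (1.72 log units; beyond the scatter) shows that the piperidine-containing side chain with the methylated nitrogen lies far above the piperazine-bearing chain. Compound 4 carries both the methyl and a piperazine ring, so a rise beyond the scatter is expected but short of compound 3. Compound 4 is estimated at 2 10^-6 cm/s (range 0.6 10^-6 cm/s to 6 10^-6 cm/s), a step of a 6.7-fold higher number from compound 2 to compound 4 (0.82 log units; beyond the scatter).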

Compound 4, apparent permeability: 0.7 10^-6 cm/s
Beside the measured number, compound 4's estimate is 2.9-fold (0.46 log units) above it, within the range that was stated.
By their numbers in this assay, from the lowest: compound 1; then compound 2; then compound 4; then compound 3.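

Within this assay, a step of a 7.4-fold lower number from compound 3 to compound 4 (0.87 log units; beyond the scatter) comes from 4-methylpiperazin-1-yl in place of piperidin-1-yl alone, so the end of the chain counts even with the methyl on the aromatic-ring nitrogen kept. The whole methyl(2-(4-methylpiperazin-1-yl)ethyl)amino group gives only a 2.3-fold higher number from compound 2 to compound 4 (0.37 log units; beyond the scatter), yet it still shows a 7.0-fold higher number from compound 1 to compound 4 (0.85 log units; beyond the scatter) against the 4-(2-(dimethylamino)ethyl)piperazin-1-yl group. Nothing here gives a measured reason for these steps. What the compounds shown leave open is how a morpholine ring at the chain end would compare, and how the 4-methylpiperazin-1-yl chain would read with a hydrogen in place of that nitrogen's methyl.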